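A few compounds are considered here, and "the series" means these few. Any claim that something is new, unique, unknown or untested is made for them only; others in the source may bear on it.

Among the compounds measured here, compound 1 `FC(F)(F)Oc1ccc(Oc2ccnc(N3CCC(NC(=S)Nc4cccnc4)CC3)c2Cl)c(Cl)c1` gives the lowest number: in an assay on membranes from brain for binding affinity to Lysophosphatidylserine lipase ABHD12 (Mus musculus), read by fluorescence, with a stated time of 20 min (on this read-out higher numbers stand for weaker inhibition and lower numbers for stronger inhibition), compound 1 gives 11 nM. The nearest neighbour is compound 2 `S=C(Nc1cccnc1)NC1CCN(c2cc(OCc3ccccc3)ccn2)CC1`, which in this assay gives 2800 nM, a gap far beyond the usual scatter. Compound 3 `FC(F)(F)Oc1ccc(Oc2ccnc(N3CCC[C@H](NC(=S)Nc4cccnc4)C3)c2Cl)c(Cl)c1` reaches only a limit of the measurement: in this assay compound 3 gives > 100000 nM, which is a limit and not a number, (the limit of > 100000 nM in this assay, at which 1 of the 3 values shown sits).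

Compound 4 `FC(F)(F)Oc1cccc(Oc2ccnc(N3CCC(NC(=S)Nc4cccnc4)CC3)c2Cl)c1` differs from compound 1 in a single place: a group of 11 heavy atoms (7 carbon, 1 oxygen, 3 fluorine; one six-membered aromatic ring of carbon only) in place of a group of 12 heavy atoms (7 carbon, 1 oxygen, 3 fluorine, 1 chlorine; one six-membered aromatic ring of carbon only), on an oxygen on an aromatic ring. The ring carrying the trifluoromethoxy group thus loses its chlorine and becomes a 3-(trifluoromethoxy)phenyl group, while the rest of the molecule stays as in compound 1.

Within the data shown here, no measured pair in this set shows how this change alone moves the result, so the expectation rests on compound 1 alone. Compound 4 is expected to remain a strong inhibitor in this assay, with a modest step toward weaker inhibition that may not exceed the scatter, a 3.6-fold higher number from compound 1 to compound 4 (0.56 log units; beyond the scatter). The estimate for compound 4 in this assay is 40 nM, within a range from 10 nM to 200 nM.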

Compound 4, half-maximal inhibitory concentration: 89 nM
Compound 4: the middle estimate sits 2.2-fold (0.35 log units) below what was measured, and the stated range covers the measured number.
By their numbers in this assay, from the lowest: compound 1; then compound 4; then compound 2. At a limit, above all of these: compound 3.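

Among these compounds, compound 1 and compound 4 form the first measured pair that isolates a single change: the chlorine is lost from the aromatic ring on the oxygen, leaving a 3-(trifluoromethoxy)phenyl group. In this assay, this gives an 8.1-fold higher number from compound 1 to compound 4 (0.91 log units; beyond the scatter), so the chlorine matters to the measured result, and the rise in the number lies beyond the usual scatter. The change is modest, however, and without the chlorine compound 4 still gives 89 nM in the same assay, so this chlorine is not essential for inhibition in the nanomolar range.

As far as these compounds go, it remains open whether a methyl group or a bromine atom in place of this chlorine would keep the number as low as in compound 1. Nothing measured here bears on why this change moves the number.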